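Bromo to nitro on the shared core: expected toxicity

This account rests on a few compounds, and the source may have more. Where it says the series, first, only, none or still open, it means among the compounds named here.

Compound 1, `COc1ccc(OCC2=NCCO2)cc1`, gives 70% in a toxicity assay on the whole organism with Rattus norvegicus as the target, at a dose of 200 mg/kg by the oral route; on this read-out lower numbers stand for a weaker effect and higher numbers for a stronger effect at the one dose given.
Compound 2, `Cc1ccccc1OCC1=NCCO1`, gives 60% in this assay.
Compound 3, `Brc1ccc(OCC2=NCCO2)cc1`, gives 80% in this assay.

Of these three numbers, compound 3 and compound 1 lie within the scatter of each other, while compound 2 sits beyond the scatter, lower than compound 3. Compound 4, `O=[N+]([O-])c1ccc(OCC2=NCCO2)cc1`, differs from compound 3 in one place: nitro in place of bromo on an aromatic carbon. Among the measured compounds shown here, no measured step swaps bromo for nitro. For the measured compounds named here, the only measured step at this same aromatic carbon, a number 10 percentage points higher from compound 1 to compound 3 (within the scatter), stayed within the scatter, so a change of the group at this place has so far left this assay essentially unchanged. For compound 4 no step beyond the scatter is expected, a number 5 percentage points lower from compound 3 to compound 4 (within the scatter). The estimate for compound 4 is therefore 75%, with a range from 55% to 95%.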

Compound 4, a percentage reported as activity, at one dose (the size of the read-out at that dose, not a potency): 70%
For compound 4 the middle estimate is 5 percentage points above the measured one, within the range that was stated.
By their numbers in this assay, from the lowest: compounds 2, 1, 4 and 3 (each within the scatter of the next, the first and the last beyond it).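

Nitro is a third group at this aromatic carbon, and in this assay the result is a number 10 percentage points lower from compound 3 to compound 4 (within the scatter) and no change at the digits printed from compound 1 to compound 4 (within the scatter). Bromo, methoxy and nitro therefore cannot be told apart at this place in this read-out, even though nitro brings 3 heavy atoms where bromo has 1. Nothing available explains why these groups read so alike.

Still open, as far as these compounds go, is whether an amine or a carboxylic acid at this carbon would also stay within the scatter. From the compounds shown here alone, it is equally open whether any group here can move the number beyond it.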